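Aryl swap at the shared core of compound 1

This account rests on a few compounds, and the source may have more. Where it says the series, first, only, none or still open, it means among the compounds named here.

In a functional assay on CHO-K1 cells for antagonist activity at adenosine receptor A1 (Homo sapiens), read by a beta-galactosidase reporter and cAMP accumulation, with stated times of 15 min and 6 h (a higher number here means a weaker inhibitor, a lower number a stronger inhibitor), compound 1 `Nc1nc(-c2ccc(C(F)F)o2)nc2sc(Cc3ccccc3)cc12` gives 3000 nM, the highest of the three numbers in hand. Compound 2 `COc1ccccc1Cc1cc2c(N)nc(-c3ccc(C(F)F)o3)nc2s1` gives 516 nM. Among the measured compounds shown here, the one single-point step measured so far is a 5.8-fold lower number from compound 1 to compound 2 (0.76 log units; beyond the scatter). Compound 3 `Cc1csc(-c2nc(N)c3cc(Cc4ccccc4F)sc3n2)n1` gives 28.6 nM, but it differs from compound 1 in two places, so only its value can be noted. Compound 4 `N#Cc1cccc(-c2nc(N)c3cc(Cc4ccccc4)sc3n2)c1` differs from compound 1 by 3-cyanophenyl in place of 5-(difluoromethyl)furan-2-yl on an aromatic carbon. For the measured compounds named here, no measured step changes this group on its own, so the expectation rests on the spread of the series rather than on a matching precedent. A step of a 2.0-fold lower number from compound 1 to compound 4 (0.30 log units; within the scatter) is expected, toward a lower number, with wide uncertainty. Compound 4 is estimated at 1500 nM, within 300 nM to 7000 nM.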

Compound 4, inhibition constant: 222 nM
Compound 4: middle estimate off by 6.8-fold (0.83 log units), on the high side; the whole stated range lies above it.
By their numbers in this assay, from the lowest: compound 3; then compound 4; then compound 2; then compound 1.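

Among the compounds shown here, putting 3-cyanophenyl in place of 5-(difluoromethyl)furan-2-yl on this aromatic carbon of the shared core gives a 14-fold lower number from compound 1 to compound 4 (1.13 log units; beyond the scatter) in this assay and is the first measured change at this position. The position therefore responds to the aryl group it carries, and a six-membered aromatic ring of carbon only reads better there than the furan of compound 1. Nothing available explains the size of this step.

On these data alone, whether the step depends on the nitrile remains open. A plain phenyl, or a carboxylic acid or an amine in place of the nitrile, could read either way.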